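Shifting a Fluorine on the Benzyl Group

The source may report more compounds than this note shows. Statements on the series, on what has been measured and on what is new or still open speak of the compounds shown alone.

Measured so far:
compound 1 `Cc1cccc(CN2CCC(c3noc(COc4ccc(/C=C/C(=O)NO)cc4)n3)CC2)c1` — 73%
compound 2 `O=C(/C=C/c1ccc(OCc2nc(C3CCN(Cc4cccc(F)c4)CC3)no2)cc1)NO` — 73%

In an assay on isolated protein for inhibition of protein deacetylase HDAC6 (Homo sapiens), read by fluorescence, with a stated time of 1 h, tested at 100 nM (on this read-out higher numbers stand for more inhibition at the one concentration tested (going by the name of the read-out) and lower numbers for less inhibition), compound 1 gives 73% and compound 2 gives 73%, and the step of no change at the digits printed from compound 1 to compound 2 (within the scatter) is within the scatter, so compound 2 stands level with compound 1. Compound 3 `O=C(/C=C/c1ccc(OCc2nc(C3CCN(Cc4ccc(F)cc4)CC3)no2)cc1)NO` differs from compound 2 by 4-fluorophenyl in place of 3-fluorophenyl on a saturated chain carbon bound to an amine nitrogen in a ring, a 3-fluorobenzyl becoming a 4-fluorobenzyl. Within the data shown here, no measured step moves the fluorine on this ring; the one step at this place, fluoro for methyl, changed nothing beyond the scatter. Compound 3 is therefore expected to stay level, with the step of no change at the digits printed from compound 2 to compound 3 (within the scatter) estimated as no change beyond the scatter. The estimate for compound 3 is 73%, between 60% and 84%.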

Compound 3, a percentage reported as inhibition, at one concentration (the size of the read-out at that concentration, not a potency): 75%
The estimate for compound 3 lay 2 percentage points below the measured number, and the stated range covers the measured number.
By their numbers in this assay, from the lowest: compounds 1, 2 and 3 (each within the scatter of the next).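

In this assay the fluorine's place on the benzyl group now has its own step, a number 2 percentage points higher from compound 2 to compound 3 (within the scatter), so 3-fluorobenzyl and 4-fluorobenzyl are not told apart at this position. The wider change from 3-methylphenyl to 4-fluorophenyl gives a number 2 percentage points higher from compound 1 to compound 3 (within the scatter) and also stays inside the scatter. Nothing at hand bears on why these numbers stay level. Going by these compounds, whether a carboxylic acid or an amine on this ring would keep the same level remains open. So does how these three compounds compare at any other concentration; only one was tested.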